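This account rests on a few compounds, and the source may have more. Where it says the series, first, only, none or still open, it means among the compounds named here.

Measured so far:

- compound 1 `Cc1nc(-c2ccccc2)c(C(=O)N2CCN(c3cccc(Cl)c3Cl)CC2)o1`: 133 nM
- compound 2 `CC(=O)c1ccc(N2CCN(C(=O)c3oc(C)nc3-c3ccccc3)CC2)cc1`: "not active" (no number reported)
- compound 3 `Cc1nc(-c2ccccc2)c(C(=O)N2CCN(c3ccc(C(=O)C(C)C)cc3)CC2)o1`: "not active" (no number reported)

These three compounds share a core and differ only in the aryl group carried on the ring nitrogen. In a functional assay on HL-60 cells (Homo sapiens) for inhibition, read by MTT assay, with a stated time of 72 h (a lower number here means a stronger inhibitor, a higher number a weaker inhibitor), compound 1 gives 133 nM. Compound 2, by contrast, is recorded in this assay as "not active" (no number reported), so no single number stands for it. Compound 3 is the one further entry of that kind, also reported in this assay as "not active" (no number reported) without a number. Compound 2 therefore stands outside the measurable range of this set, with only compound 1 giving a figure to compare against.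

The next compound, compound 4 `COc1cccc(N2CCN(C(=O)c3oc(C)nc3-c3ccccc3)CC2)c1`, has not yet been measured. It is built from compound 2 by the change (3-methoxyphenyl in place of 4-acetylphenyl on an amine nitrogen in a ring). Going by the values given here, no measured pair shows this exact step, so its size cannot be read from the data; with compound 2 giving no number, the direction is unknown, and anything from no change to a clear gain in potency is possible.

In this assay compound 4 is expected to give about 3000 nM, with a range from 300 nM to 30000 nM.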

Compound 4, half-maximal inhibitory concentration: 34.8 nM
For compound 4 the middle estimate is 86-fold (1.94 log units) above the measured one; measured number below the stated range.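

In this assay, putting 3-methoxyphenyl in place of 2,3-dichlorophenyl on the amine nitrogen in the ring gives a 3.8-fold lower number from compound 1 to compound 4 (0.58 log units; beyond the scatter), a modest but real gain, so the dichlorinated ring is not needed for activity at this position. Compound 4 also carries a number while compound 2, with 4-acetylphenyl at the same place, is recorded without one, which shows that swapping one substituted phenyl group for another here can separate a potent compound from one with no reported activity, although the size of that step cannot be read. Nothing in the data explains why these groups differ in this way.

As far as these compounds go, what remains open is which feature of the 3-methoxyphenyl group matters, since a plain phenyl, a 3-hydroxyphenyl or a 3-ethoxyphenyl group would be needed to separate the role of the methoxy group from that of the ring alone. The compounds shown also leave open whether any other change on this ring, such as a fluorine or an amine, would go beyond compound 4.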